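This account rests on a few compounds, and the source may have more. Where it says the series, first, only, none or still open, it means among the compounds named here.

Compound 1 `O=C(O)C[C@@H]1CCCN1c1ccc(OCc2ccc(Cl)cc2Cl)cn1` gives 220 nM
Compound 2 `COc1ccc(F)c(-c2ccc(Cc3ccc(N4C[C@H](C(F)(F)F)C[C@@H]4CC(=O)O)cc3)c(C)c2)c1` gives 110 nM

Both compounds were tested in a functional assay on cells for agonist activity at Free fatty acid receptor 1 (Homo sapiens), read by FLIPR and calcium flux, with a stated time of 100 s; on this read-out higher numbers stand for an effect only at larger amounts of compound and lower numbers for an effect already at smaller amounts. Compound 2 gives 110 nM, and compound 1 gives 220 nM. The gap between these two numbers is within the scatter of repeated measurements, so the two compounds cannot be told apart on this read-out, and neither can be called the more potent one.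

Compound 3 `COc1ccc(F)c(-c2ccc(Cc3ccc(N4C[C@@H](C(F)(F)F)C[C@@H]4CC(=O)O)cc3)c(C)c2)c1` has not been measured yet. It is built from exactly the same atoms and bonds as compound 2: the two compounds have the same atoms and bonds and differ only in configuration as drawn: 1 of 2 stereo elements differ; a stereocentre at a saturated ring carbon is drawn R in compound 2 and S in compound 3. In plain terms, the trifluoromethyl-bearing carbon of the saturated ring points its substituent the other way in space, while everything else, including the second stereocentre, stays as it was.

Among the measured compounds shown here, no pair of measured compounds here differs only in such a configuration, so there is no direct precedent to lean on. A flip at a ring stereocentre can leave potency unchanged or shift it considerably in either direction. For compound 3 the expectation is a moderate step in this assay toward a higher number, a 2.7-fold higher number from compound 2 to compound 3 (0.44 log units; beyond the scatter), with wide uncertainty. The expected value for compound 3 is 300 nM, in a range from 60 nM to 1500 nM.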

Compound 3, half-maximal effective concentration: 150 nM
For compound 3 the middle estimate is 2.0-fold (0.30 log units) above the measured one, and the stated range covers the measured number.
By their numbers in this assay, from the lowest: compounds 2, 3 and 1 (each within the scatter of the next).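

Turning the trifluoromethyl-bearing ring carbon from R to S gives, in this assay, a 1.4-fold higher number from compound 2 to compound 3 (0.13 log units; within the scatter), so compound 2 and compound 3 cannot be told apart on this read-out. Among the compounds shown here, this is the first pair in the set that can be compared directly, and it isolates a single feature, the direction in which one substituent points in space, with nothing else altered: the fact that compounds 2 and 3 differ only in the configuration as drawn. With the rest of the molecule held fixed, this read-out therefore shows no detectable preference between the two configurations at this carbon, a statement that holds for this pair alone and cannot be extended to other compounds carrying a similar ring.

What remains open is whether the trifluoromethyl group itself matters at this carbon, as the compounds shown give no view of a methyl group, a hydroxyl group or a plain hydrogen in its place. Also open, as far as these compounds go, is whether the second stereocentre of the saturated ring is as undemanding as this one, as every compound here with that ring has it drawn the same way.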